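From 4-fluorophenyl to 3-hydroxy-4-methoxyphenyl on the carbonyl

The compounds below may be only part of what the source reports. "The series", "measured", "known", "first", "only" and "open" are said of these compounds alone.

Values in a functional assay on HT-29 cells (Homo sapiens) for inhibition, read by MTT assay, with a stated time of 48 h; on this read-out lower numbers stand for stronger inhibition and higher numbers for weaker inhibition:
compound 1 `COc1ccc(-n2c(S)nnc2-c2cc(OC)c(OC)c(OC)c2)cc1`: > 60000 nM (a limit)
compound 2 `COc1ccc(-n2c(SCC(=O)c3ccc(F)cc3)nnc2-c2cc(OC)c(OC)c(OC)c2)cc1`: 42500 nM (a measured number)

Among the compounds with values here, compound 2 holds the only actual number so far, and the other value is a limit. Compound 3 `COc1ccc(-n2c(SCC(=O)c3ccc(OC)c(O)c3)nnc2-c2cc(OC)c(OC)c(OC)c2)cc1` keeps everything in compound 2 except the aryl group on the carbonyl carbon, where 3-hydroxy-4-methoxyphenyl takes the place of 4-fluorophenyl: 3-hydroxy-4-methoxyphenyl in place of 4-fluorophenyl on a carbonyl carbon.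

Within the data shown here, one measured step bears on this, an at least 1.4-fold lower number from compound 1 to compound 2 (0.14 log units; that floor lies within the scatter), and it concerns the whole side chain on sulfur. Among the measured compounds shown here, no step has been measured at the aryl group itself. That gives little guidance on size, so a lower number in this assay is expected only tentatively and with a wide range. The expected move is a 5.3-fold lower number from compound 2 to compound 3 (0.73 log units; beyond the scatter). For compound 3 the estimate is 8000 nM, with an expected range from 500 nM to 55000 nM.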

Compound 3, half-maximal inhibitory concentration: > 60000 nM
Compound 3 was reported as a limit; the forecaster's own chance of this, stated with the estimate: 15%; middle value at least 7.5-fold (0.87 log units) from the limit.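

Within the data shown here, the aryl group on the carbonyl carbon is read directly here for the first time: in this assay, 3-hydroxy-4-methoxyphenyl in place of 4-fluorophenyl gives an at least 1.4-fold higher number from compound 2 to compound 3 (0.14 log units; that floor lies within the scatter). That floor leaves the size of the step unsettled, but the change brings no lower number, and the step from compound 1 to compound 3 cannot be read, as both ends are limits. Further changes that weaken this series will be hard to size, with most readings now at a single ceiling: the limit of > 60000 nM in this assay, at which 2 of the 3 values shown sit.

From the compounds shown here alone, how far compound 3 lies beyond its limit stays open, as does whether any aryl group at this position can give a number well under that of compound 2. Also open, going by these compounds, is what an amine or a carboxylic acid on the aryl group, or a longer chain on sulfur, would give.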